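Removing a methyl from an oxygen: compound 2 to compound 4

The compounds below may be only part of what the source reports. "The series", "measured", "known", "first", "only" and "open" are said of these compounds alone.

Three compounds share a core in which a nitrile-bearing chain sits on a nitrogen of the central ring system. Compound 1 `COc1cc(C)cc(-c2c(-c3ccnc(-c4ccc(N(C)C)cc4)c3)cnn2CC#N)c1`, compound 2 `COc1cc(C)cc(-c2nn(CC#N)cc2-c2ccnc(-c3ccc(N(C)C)cc3)c2)c1` and compound 3 `COc1cc(C)cc(-c2nn(CC#N)cc2-c2ccc(-c3cccc(C(C)=O)c3)nc2)c1` were each tested in a functional assay on MOLT-4 cells (Homo sapiens) for cytotoxicity, read by sulforhodamine B assay, with a stated time of 48 h, tested at 0.001 uM; on this read-out higher numbers stand for a weaker effect at the one concentration tested and lower numbers for a stronger effect. In this assay compound 1 gives 96%, compound 2 gives 102% and compound 3 gives 97%. Compound 2 shows the highest of the three numbers, but its gaps to compound 3 and to compound 1 both lie within the scatter, so the three read as one and the same picture: at this concentration none of them shows a clear effect on the cells.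

Compound 4 `Cc1cc(O)cc(-c2nn(CC#N)cc2-c2ccnc(-c3ccc(N(C)C)cc3)c2)c1` differs from compound 2 in one place: hydrogen in place of methyl on an oxygen on an aromatic ring. Going by the values given here, no measured pair in this set shows what this kind of change does, so the expectation can rest only on the values of compound 2 and its neighbours. Compound 4 is expected to sit at 99%, within a range from 88% to 110%. Among the compounds with values here, the step expected is a number 3 percentage points lower from compound 2 to compound 4 (within the scatter), that is, nothing beyond the scatter, because compound 2 already gives 102% and every compound so far reads about the same.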

Compound 4, a percentage reported as activity, at one concentration (the size of the read-out at that concentration, not a potency): 100%
Compound 4: the middle estimate sits 1 percentage points below what was measured; the measured number falls inside the stated range.
By their numbers in this assay, from the lowest: compounds 1, 3, 4 and 2 (each within the scatter of the next).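

Swapping methoxy for hydroxy on the 3-methoxy-5-methylphenyl group gives a number 2 percentage points lower from compound 2 to compound 4 (within the scatter) in this assay. Going by these compounds alone, this is the first pair in the set that differs in only one place, and it shows that at this single low concentration, removing the methyl from this oxygen does not bring out a clear effect on the cells, so compound 4 reads like the others. No measurement available here bears on what lies behind this result.

Within the data shown here, with every compound so far reading about the same, this test cannot show whether the position matters at all, and a read-out at a greater concentration could still separate compound 2 from compound 4. Also open, going by these compounds, is what an ethoxy group, an amine or a carboxylic acid at this place on the ring would do.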